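A few compounds are considered here, and "the series" means these few. Any claim that something is new, unique, unknown or untested is made for them only; others in the source may bear on it.

Compound 1 `O=S(=O)(O)OCCCCCCCCCCCC[Se]c1ccccc1`: > 100000 nM
Compound 2 `O=S(=O)(O)OCCCCCCCC[Se]c1ccccc1`: > 100000 nM

Both entries come from a functional assay on HCT-116 cells (Homo sapiens) for cytotoxicity, read by MTT assay, with a stated time of 24 h (on this read-out lower numbers stand for stronger inhibition and higher numbers for weaker inhibition), and neither is a number: each is a limit of the assay. Compound 2 therefore stands only at its limit of > 100000 nM, which is the limit of > 100000 nM in this assay, at which 2 of the 2 values shown sit. Compound 3 `O=S(=O)(O)OCCCCCCCCC[Se]c1ccccc1` has not yet been measured. It differs from compound 2 in one place: (sulfooxy)methyl in place of sulfooxy on a saturated chain carbon, eight bonds along the chain from a selenium atom, with (sulfooxy)methyl in place of sulfooxy on a saturated chain carbon, eight bonds along the chain from a selenium atom. In this assay, no change beyond the scatter is expected, so the expected step of a number no higher from compound 2 to compound 3 (the limit leaves the size open) is small and has no clear direction. Compound 3 is estimated at 100000 nM, within a range of 50000 nM to 200000 nM.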

Compound 3, half-maximal inhibitory concentration: > 100000 nM
Compound 3 was reported as a limit; the forecaster's own chance of this, stated with the estimate: 85%; the middle value lies on the limit itself.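

The steps from compound 1 and from compound 2 to compound 3 cannot be read, because all three compounds stand only as limits in this assay: the limit of > 100000 nM in this assay, at which 3 of the 3 values shown sit.

The compounds shown leave open whether any of them has a measurable value in this assay, and how the chain affects it.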